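This account rests on a few compounds, and the source may have more. Where it says the series, first, only, none or still open, it means among the compounds named here.

In an ADME assay on HEK293 cells (Homo sapiens) for cytotoxicity, read by resazurin assay, with a stated time of 48 h (a lower number here means that less compound is tolerated, a higher number that more compound is tolerated), compound 1 `COc1ccc(Cl)cc1S(=O)(=O)Nc1ccc(-c2nc3ccccc3o2)cc1` gives 75000 nM. Compound 2 `C=Cc1ccc(S(=O)(=O)Nc2ccc(-c3nc4ccccc4o3)cc2)cc1` gives > 100000 nM, which is a limit of the assay rather than a number. Compound 3 `O=S(=O)(Nc1ccc(-c2nc3ccccc3o2)cc1)c1cccc(O)c1` also gives > 100000 nM, again a limit of the assay and not a number. The measured steps are an at least 1.3-fold higher number from compound 1 to compound 2 (0.12 log units; that floor lies within the scatter) and an at least 1.3-fold higher number from compound 1 to compound 3 (0.12 log units; that floor lies within the scatter), each given only as a floor, while a step that the two limits leave unreadable from compound 2 to compound 3. Compound 3 thus stands at the limit of > 100000 nM in this assay, at which 2 of the 3 values shown sit, and none of the three compounds shows a step beyond the scatter. Compound 4 `O=S(=O)(Nc1ccc(-c2nc3ccccc3o2)cc1)c1ccc(O)cc1` has not yet been measured; it differs from compound 3 by 4-hydroxyphenyl in place of 3-hydroxyphenyl on a sulfonyl sulfur. Among the measured compounds shown here, no measured step exchanges one hydroxyphenyl for another, so the only guide is that two quite different groups on the sulfonyl sulfur both sit at the same limit. The step of a number no higher from compound 3 to compound 4 (the limit leaves the size open) is therefore expected to be none beyond the scatter. Compound 4 is expected at 100000 nM, within a range from 50000 nM to 200000 nM, most likely reported once more as a limit.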

Compound 4, half-maximal cytotoxic concentration: > 100000 nM
Compound 4: only a limit was reported (the forecaster's own chance of this, stated with the estimate: 70%); the middle value lies on the limit itself.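

In this assay compound 4 gives > 100000 nM, which is a limit of the assay and not a number. Thus 4-hydroxyphenyl in place of 3-hydroxyphenyl on the sulfonyl sulfur, a change that only rearranges the same atoms, leaves the reading at the limit already shared by two other compounds: the limit of > 100000 nM in this assay, at which 3 of the 4 values shown sit. Among the compounds shown here, the steps linking compound 2, compound 3 and compound 4 cannot be read, and the one readable new step, an at least 1.3-fold higher number from compound 1 to compound 4 (0.12 log units; that floor lies within the scatter), is only a floor.

On these data alone, how far compound 2, compound 3 and compound 4 actually lie from one another remains open, including whether the two hydroxyphenyl groups differ at all. Also open, as far as these compounds go, is how an amine or a carboxylic acid in place of the hydroxy group would read in this assay.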